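This account rests on a few compounds, and the source may have more. Where it says the series, first, only, none or still open, it means among the compounds named here.

Measured so far in an ADME assay on MT2 cells (Homo sapiens) for cytotoxicity, read by XTT assay, with a stated time of 4 days; on this read-out higher numbers stand for lower toxicity in this test and lower numbers for higher toxicity in this test:
compound 1 `Cc1nc(C(NC(=O)C(=O)Nc2ccc(F)c(F)c2)C2CCCCN2)sc1CO`: > 87000 nM.
compound 2 `CC(=O)c1ccc(NC(=O)C(=O)NC(c2nc(C)c(CCO)s2)C2CCCCN2)cc1`: > 48300 nM.
compound 3 `Cc1nc(C(NC(=O)C(=O)Nc2ccc(Cl)cc2)C2CCCNC2)sc1CCO`: > 78500 nM.

Compound 1 gives the reading > 87000 nM, which is a limit of this assay, not a number. For compound 2 the reading > 48300 nM is likewise a limit. For compound 3 the reading > 78500 nM is a limit as well. Compound 1 therefore stands where all three sit: no half-maximal cytotoxic concentration was reached within the tested range, and nothing can be ordered among them.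

Compound 4 `Cc1ccc(NC(=O)C(=O)NC(c2nc(C)c(CO)s2)C2CCCCN2)c(F)c1` is not yet measured. It differs from compound 1 in one place: 2-fluoro-4-methylphenyl in place of 3,4-difluorophenyl on an amide-type nitrogen. No measured pair covers a change of this kind in this assay. The step is expected to be an at least 1.0-fold lower number from compound 1 to compound 4 (0.03 log units; that floor lies within the scatter), none beyond the usual scatter. Compound 4 is expected to give 80000 nM, within 40000 nM to 160000 nM, most probably again reported as a limit rather than a number.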

Compound 4, half-maximal cytotoxic concentration: > 109000 nM
Compound 4 ended at the assay's limit; the forecaster's own chance of this, stated with the estimate: 85%; at least 1.3-fold (0.13 log units) between middle value and limit.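

Among the compounds shown here, compound 1 and compound 4 both end at limits in this assay, and no step between them can be read. The compounds shown leave open where any half-maximal cytotoxic concentration lies, and whether 2-fluoro-4-methylphenyl in place of 3,4-difluorophenyl changes it.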